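The source may report more compounds than this note shows. Statements on the series, on what has been measured and on what is new or still open speak of the compounds shown alone.

Of the compounds shown here, three sharing a core have been tested in a functional assay for inhibition, with Rattus norvegicus as the target (a lower number here means a stronger inhibitor, a higher number a weaker inhibitor), so far. There compound 1 (`CCOC(=O)c1c(CC)c(OC)c2ccccc2c1OC(C)=O`) gives 3760 nM while compound 3 (`CCCc1c(CCC)c(OC(C)=O)c2ccccc2c1OC`) gives 1430 nM and compound 2 (`CCCCCc1c(C(=O)OCC)c(OC)c2ccccc2c1OC(C)=O`) gives 940 nM on the same scale. Compound 2 and compound 3 lie within the scatter of each other, whereas the gap from compound 2 up to compound 1 lies beyond it. Compound 4 (`CCOC(=O)c1c(CC)c(OC(C)=O)c2ccccc2c1OC`) has not yet been measured. It differs from compound 2 by one change (hydrogen in place of propyl on a saturated chain carbon, two bonds along the chain from an aromatic carbon) that puts hydrogen in place of propyl on a saturated chain carbon, two bonds along the chain from an aromatic carbon, so that pentyl becomes ethyl. Among the measured compounds shown here, no measured pair isolates this change. The nearest guide is compound 1 at 3760 nM as it also carries ethyl, so a higher number, meaning a weaker inhibitor, is expected in this assay. The expected change is a 2.6-fold higher number from compound 2 to compound 4 (0.41 log units; beyond the scatter) and it would probably lie beyond the scatter. The estimated value for compound 4 is 2400 nM with an expected range from 900 nM to 6000 nM as its likely span.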

Compound 4, half-maximal inhibitory concentration: 1160 nM
The estimate for compound 4 lay 2.1-fold (0.32 log units) above the measured number, within the range that was stated.
By their numbers in this assay, from the lowest: compounds 2, 4 and 3 (each within the scatter of the next); then compound 1.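

In this assay, among the compounds shown here, the step of a 1.2-fold higher number from compound 2 to compound 4 (0.09 log units; within the scatter) gives the first pair in this set that differs in one place only, and it isolates hydrogen in place of propyl on a saturated chain carbon, two bonds along the chain from an aromatic carbon. With pentyl cut back to ethyl, the two compounds cannot be told apart in this assay, so at this position the outer part of the chain is not needed to hold the reading within the scatter. Chain lengths from ethyl to pentyl therefore read alike on this one pair, although intermediate lengths on this same arrangement do not appear here.

On these data alone, whether a longer chain such as octyl, or a chain ending in an amine or a carboxylic acid, would read alike at this position remains open. Nothing given here explains why ethyl and pentyl read alike.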